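Halogen swap on the aryl group of an oxazole-fused core

This account rests on a few compounds, and the source may have more. Where it says the series, first, only, none or still open, it means among the compounds named here.

Measured compounds:
compound 1 `c1ccc(CNc2ccc3nc(-c4ccccc4)oc3n2)cc1` — 4.8%
compound 2 `c1ccc(-c2nc3ccc(N4CCCCCC4)nc3o2)cc1` — 57.9%
compound 3 `Fc1ccccc1-c1nc2ccc(N3CCCCC3)nc2o1` — 94.9%

Three compounds were tested in an assay on isolated protein for inhibition of Amine oxidase [flavin-containing] B (Homo sapiens), read by fluorescence, with a stated time of 1 h, tested at 10 uM; on this read-out higher numbers stand for more inhibition at the one concentration tested (going by the name of the read-out) and lower numbers for less inhibition. Compound 1 gives 4.8%, the lowest number of the set. Compound 2, which carries an azepane ring on the shared core, gives 57.9%. Compound 3, with a piperidine ring and a 2-fluorophenyl group, gives 94.9%, the highest number of the three: compound 2 sits a good deal lower, beyond the scatter, and compound 1 lies far lower still. Compound 2 and compound 3 differ in two places at once, so the shown values do not separate the effect of the ring from that of the halogen on the aryl group.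

Compound 4 `Clc1cccc(-c2nc3ccc(N4CCCCC4)nc3o2)c1` has not yet been measured in this assay. It differs from compound 3 in one place: 3-chlorophenyl in place of 2-fluorophenyl on an aromatic carbon. For the measured compounds named here, no pair of measured compounds isolates such a change on the aryl group, so the expectation rests only on the high value of compound 3 in this assay. For compound 4 a modest drop or no change beyond the scatter is expected, as a number 9.9 percentage points lower from compound 3 to compound 4 (within the scatter). Compound 4 is thus estimated at 85%, with a range from 55% to 98%.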

Compound 4, a percentage reported as inhibition, at one concentration (the size of the read-out at that concentration, not a potency): 91.7%
Estimate against measurement, compound 4: 6.7 percentage points below; low and high end bracket the measured number.
By their numbers in this assay, from the lowest: compound 1; then compound 2; then compounds 4 and 3 (each within the scatter of the next).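

In this assay, placing 3-chlorophenyl instead of 2-fluorophenyl on the aromatic carbon next to the ring nitrogen and next to the ring oxygen gives a number 3.2 percentage points lower from compound 3 to compound 4 (within the scatter). With the piperidine ring held constant, this first single-place comparison in the set shows that the position accepts this change of aryl group with no shift that can be told from the scatter. Both compounds lie near the top of the percentage scale at the one concentration tested, so this read-out may not reveal a difference in potency between them, and no measurement at hand accounts for their similar values.

The compounds shown leave open whether a halogen on the phenyl ring is needed at all and whether the identity of the halogen or its place on the ring matters on its own, as this step changes both at once. They also leave open how a methoxy group, a nitrile or a carboxylic acid on the phenyl ring would fare at this position.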